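Para-phenyl in place of trifluoromethoxy on the acrylic acid series

The source may report more compounds than this note shows. Statements on the series, on what has been measured and on what is new or still open speak of the compounds shown alone.

Measured compounds:
compound 1, `COC(=O)/C=C/c1ccc2noc(-c3ccccc3)c2c1`, 1580 nM in an assay for inhibition of inositol hexakisphosphate kinase 2 (Homo sapiens), read by colorimetric assay, coupled enzyme assay and malachite green, with a stated time of 120 min, in the presence of a further agent that is not named here; a higher number here means a weaker inhibitor, a lower number a stronger inhibitor
compound 2, `O=C(O)/C=C/c1ccc2noc(-c3ccc(OC(F)(F)F)cc3)c2c1`, 320 nM in this assay

Among the measured compounds shown here, of the two numbers so far, compound 2 has the lower one, and its nearest neighbour is compound 1, whose number is higher by a margin that lies beyond the scatter of repeated measurements. Compound 1 and compound 2 differ in two places, the ester against the acid and the bare phenyl against the substituted one, so the two values alone cannot be split into separate contributions.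

Compound 3, `O=C(O)/C=C/c1ccc2noc(-c3ccc(-c4ccccc4)cc3)c2c1`, keeps the acid of compound 2 and alters the pendant ring: phenyl in place of trifluoromethoxy on an aromatic carbon. For the measured compounds named here, no single-point step is available to calibrate this exchange, so the direction of the change in this assay is open. The author expects no step beyond the usual scatter, with a wide band around that centre, which is what a 1.3-fold higher number from compound 2 to compound 3 (0.10 log units; within the scatter) conveys. For compound 3 the estimate in this assay is therefore 400 nM, with a range from 100 nM to 1600 nM.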

Compound 3, half-maximal inhibitory concentration: 74 nM
Beside the measured number, compound 3's estimate is 5.4-fold (0.73 log units) above it, and the stated range ends above it.
By their numbers in this assay, from the lowest: compound 3; then compound 2; then compound 1.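

Among the compounds shown here, with the acid held constant, exchanging trifluoromethoxy for phenyl on the pendant ring gives a 4.3-fold lower number from compound 2 to compound 3 (0.64 log units; beyond the scatter) in this assay, the first comparison that differs in one place only. It shows that this place, para to a large group, accepts an additional six-membered aromatic ring of carbon only, and that the number falls beyond the scatter when it does. Trifluoromethoxy carries a hydrogen-bond acceptor and phenyl carries none, so such an acceptor at this place is not required for the lower number seen with compound 3, but no measurement shown here explains why the exchange lowers the number.

On these data alone, it remains open whether the aromatic ring itself matters, or whether a saturated ring such as cyclohexyl, a pyridine ring or a simple methoxy group at the same place would give a similar number. The contribution of the carboxylic acid also remains unresolved, as compound 1 differs from both acids in its methyl ester and its bare phenyl, and a comparison with a tetrazole or an amide would be needed to isolate that position.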